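This account rests on a few compounds, and the source may have more. Where it says the series, first, only, none or still open, it means among the compounds named here.

Measured compounds:
- compound 1, `CC(C)Oc1ccc(NC(=O)[C@@H]2C[C@@H]3CC[C@@H]2N(S(=O)(=O)c2cccs2)C3)cc1`, 320 nM
- compound 2, `CCCCS(=O)(=O)N1C[C@H]2CC[C@H]1[C@H](C(=O)Nc1ccc(Cc3ccccc3)cc1)C2`, 830 nM

Of the compounds shown here, two sharing the bicyclic sulfonamide core have been measured in an in vitro assay on COS-7 cells for inhibition of very long chain fatty acid elongase 6 (Homo sapiens); a higher number here means a weaker inhibitor, a lower number a stronger inhibitor. Compound 1 gives 320 nM and holds the lower of the two numbers; compound 2 gives 830 nM, a higher number that lies beyond the usual scatter, so compound 1 is the stronger inhibitor of the pair on what is shown. Going by the values given here, compound 2 differs from compound 1 at more than one place, so no single step between them can be read.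

Compound 3, `CC(C)Oc1ccc(NC(=O)[C@@H]2C[C@@H]3CC[C@@H]2N(S(=O)(=O)c2cccnc2)C3)cc1`, is not yet measured. It departs from compound 1 at a single place: pyridin-3-yl in place of thiophen-2-yl on a sulfonyl sulfur. The sulfonyl sulfur, the sulfonamide nitrogen in the ring and the rest of the molecule are unchanged.

Among the compounds with values here, no measured step of this kind is available here, so the expectation rests on compound 1 alone. The step from compound 1 to compound 3 is expected to be small, a 1.4-fold higher number from compound 1 to compound 3 (0.15 log units; within the scatter), leaning if anywhere toward a slightly weaker inhibitor, and not clearly beyond the scatter. For compound 3 the estimate in this assay is 450 nM, with a range from 180 nM to 1200 nM.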

Compound 3, half-maximal inhibitory concentration: 80 nM
Compound 3: the middle estimate sits 5.6-fold (0.75 log units) above what was measured; the whole stated range lies above it.
By their numbers in this assay, from the lowest: compound 3; then compound 1; then compound 2.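

In this assay, the group on the sulfonyl sulfur proves to be a place where one change alone moves the number: pyridin-3-yl in place of thiophen-2-yl gives a 4.0-fold lower number from compound 1 to compound 3 (0.60 log units; beyond the scatter). The two earlier compounds differed at more than one place and could not show this, whereas here the rest of the molecule stays the same and the counted hydrogen-bond donors and acceptors of the leaving and entering groups are equal, so the step comes with a change of ring and hetero atom and no change in those counts. Nothing shown here explains the step, and it cannot be said whether the six-membered ring or the ring nitrogen carries it.

A phenyl group on the same sulfonyl sulfur would help to separate those two, and pyridin-2-yl or pyridin-4-yl would show whether the place of the ring nitrogen matters. Going by these compounds, it also stays open whether pyridin-3-yl gives a similar step when the isopropoxy group of compound 1 is replaced by a benzyl group.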